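Carbamate in place of allyloxy amidine: solubility expectation

This account rests on a few compounds, and the source may have more. Where it says the series, first, only, none or still open, it means among the compounds named here.

Three compounds share a core and differ in the group on one aromatic carbon of the six-membered ring of the fused system. In a physicochemical assay for solubility, in phosphate buffer, at pH 7.4 (on this read-out higher numbers stand for higher solubility and lower numbers for lower solubility), compound 1 `N=C(N)c1ccc2[nH]c(-c3cccc(-c4cc(F)ccc4O)c3O)cc2c1` gives 83000 nM. In this assay compound 2 `CCONC(=N)c1ccc2[nH]c(-c3cccc(-c4ccccc4O)c3O)cc2c1` gives 43000 nM, and compound 3 `C=CCO/N=C(/N)c1ccc2[nH]c(-c3cccc(-c4ccccc4O)c3O)cc2c1` gives 24000 nM. The step of a 1.8-fold lower number from compound 2 to compound 3 (0.25 log units; within the scatter) stays within the scatter, so compound 2 and compound 3 cannot be told apart on these numbers, whereas compound 1 sits higher than compound 3 by a margin beyond the scatter.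

Compound 4 `CC(C)OC(=O)NC(=N)c1ccc2[nH]c(-c3cccc(-c4ccccc4O)c3O)cc2c1` carries a group of 9 heavy atoms (5 carbon, 2 nitrogen, 2 oxygen; no ring) in place of a group of 7 heavy atoms (4 carbon, 2 nitrogen, 1 oxygen; no ring), on an aromatic carbon. For the measured compounds named here, the only measured step at this position is a 1.8-fold lower number from compound 2 to compound 3 (0.25 log units; within the scatter), a small exchange at the same carbon that moved the number little. Going by the values given here, the present exchange is larger in size, but nothing among the measured compounds shows a sizable move from such a change, so a modest step, if any, is expected, with a slight lean toward a lower number. The expected step of a 1.6-fold lower number from compound 3 to compound 4 (0.20 log units; within the scatter) is accordingly estimated to stay close to the scatter. Compound 4 is therefore expected to give about 15000 nM in this assay, within a range from 5000 nM to 45000 nM.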

Compound 4, solubility: < 10000 nM
Compound 4 ended at the assay's limit; the forecaster's own chance of this, stated with the estimate: 5%; middle value at least 1.5-fold (0.17 log units) away from the limit.
By their numbers in this assay, from the lowest: compounds 3, 2 and 1 (each within the scatter of the next, the first and the last beyond it). At a limit, below all of these: compound 4.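

In this assay, a change at this aromatic carbon now moves the reading by more than the scatter: the carbamate-bearing group of compound 4 gives an at least 2.4-fold lower number from compound 3 to compound 4 (0.38 log units; beyond the scatter), whereas the earlier exchange at the same carbon, a 1.8-fold lower number from compound 2 to compound 3 (0.25 log units; within the scatter), could not be told apart from noise. The same holds when the comparison starts from the ethoxy compound, with isopropoxycarbonyl in place of ethoxy on an amine nitrogen: an at least 4.3-fold lower number from compound 2 to compound 4 (0.63 log units; beyond the scatter). Compound 4 stands at a limit of the assay and not at a number, and the full size of both steps stays unread: the limit of < 10000 nM in this assay, at which 1 of the 4 values shown sits.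

The compounds shown do not separate the carbonyl of the new group from its isopropyl end, and a methoxycarbonyl or a longer butoxycarbonyl chain on the same nitrogen would help show which part goes with the lower reading. They also leave open how a group ending in an amine or a carboxylic acid on that chain would read in this assay.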